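Removing one carbon from a weak cytotoxic urea

A few compounds are considered here, and "the series" means these few. Any claim that something is new, unique, unknown or untested is made for them only; others in the source may bear on it.

Three ureas built on a shared core have been tested in a functional assay on MCF7 cells (Homo sapiens) for cytotoxicity, read by MTT assay, with a stated time of 48 h; a lower number here means a stronger inhibitor, a higher number a weaker inhibitor. Among the compounds with values here, compound 2 `CCc1ccc(NC(=O)N(Cc2cc(OC)c(OC)c(OC)c2)n2cnnc2)cc1` is the only one that gives a number, with 24800 nM. Compound 1 `COc1ccc(CN(C(=O)Nc2ccc(C)cc2)n2cnnc2)cc1OC` sits at the limit of the assay, reported as > 50000 nM. Compound 3 `Cc1ccsc1CN(C(=O)Nc1ccccc1)n1cnnc1` likewise reaches only the limit, > 50000 nM. Compound 2 therefore stands alone as a measured value, while the other two rest on (the limit of > 50000 nM in this assay, at which 2 of the 3 values shown sit).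

Compound 4 `COc1cc(CN(C(=O)Nc2ccc(C)cc2)n2cnnc2)cc(OC)c1OC` has not yet been measured. It differs from compound 2 in one place: hydrogen in place of methyl on a saturated chain carbon bound to an aromatic carbon, or ethyl to methyl on the phenyl ring. Within the data shown here, no measured pair shows this same change, so the size of the step is open. Since compound 2 is already weak at 24800 nM, compound 4 is expected to remain weak. Compounds 1 and 3 give no number at all, and the estimated step of a 1.6-fold higher number from compound 2 to compound 4 (0.21 log units; within the scatter) is expected to be small. Compound 4 is estimated at 40000 nM, expected between 15000 nM and 100000 nM.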

Compound 4, half-maximal inhibitory concentration: > 50000 nM
Compound 4: a limit, no number; the forecaster's own chance of this, stated with the estimate: 50%; at least 1.2-fold (0.09 log units) between middle value and limit.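

Cutting ethyl to methyl on the phenyl ring, with the rest of the molecule unchanged, gives an at least 2.0-fold higher number from compound 2 to compound 4 (0.30 log units; that floor lies within the scatter). In this assay, going by these compounds, compound 4 gives > 50000 nM, which is a limit of the assay and not a number, so the true size of this step is unknown and the data cannot show whether this one carbon matters at all. The step that joins two limits cannot be read, and the only measured number in the set now has no numbered partner to compare with: the limit of > 50000 nM in this assay, at which 3 of the 4 values shown sit.

On these data alone, what stays open is whether a longer chain, such as propyl or butyl, in the place of the ethyl group would bring the number lower. The effect of an amine or a carboxylic acid at that same place is also unknown.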